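The compounds below may be only part of what the source reports. "The series", "measured", "known", "first", "only" and "open" are said of these compounds alone.

Measured so far in an ADME assay on Vero cells (Chlorocebus sabaeus) for cytotoxicity, read by resazurin assay, with a stated time of 72 h; a higher number here means that more compound is tolerated, a lower number that less compound is tolerated:
compound 1, `O=C(/C=C/c1ccc([N+](=O)[O-])o1)c1ccc(-c2ccccc2)cc1`: > 100000 nM
compound 2, `CSc1ccc(C(=O)/C=C/c2ccco2)cc1`: "not determined" (no result reported)
compound 3, `O=C(/C=C/c1ccco1)c1ccc(N2CCCCC2)cc1`: "not determined" (no result reported)

In this assay compound 1 gives > 100000 nM, which is a limit of the assay and not a number. Compound 2 has no result in this assay, "not determined" (no result reported). Compound 3 likewise has no result, "not determined" (no result reported). Compound 1 therefore stands alone among the values shown, sitting at the limit of > 100000 nM in this assay, at which 1 of the 3 values shown sits. Going by the values given here, no pair of measured compounds differs in one place, so there is no measured step in this assay on which to build.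

Compound 4, `CCCCc1ccc(C(=O)/C=C/c2ccc([N+](=O)[O-])o2)cc1`, differs from compound 1 by butyl in place of phenyl on an aromatic carbon. With a single limit as the only reference, the expectation for this assay is no step beyond the scatter; the estimated step is a number no higher from compound 1 to compound 4 (the limit leaves the size open). Compound 4 is expected to give 100000 nM, with a range from 30000 nM to 300000 nM, and it is likely that this assay again returns only a limit for compound 4.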

Compound 4, half-maximal cytotoxic concentration: 75700 nM
The estimate for compound 4 lay 1.3-fold (0.12 log units) above the measured number; the measured number falls inside the stated range.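

In this assay, butyl in place of phenyl on an aromatic carbon, para to a large group, gives the only single number shown so far, with compound 4 at 75700 nM. The change at this position reads as an at least 1.3-fold lower number from compound 1 to compound 4 (0.12 log units; that floor lies within the scatter), so replacing the six-membered aromatic ring with a chain without a ring shows no step beyond the scatter. Compound 1 stands at a limit of the assay and not at a number, and the true size of the step stays open: the limit of > 100000 nM in this assay, at which 1 of the 4 values shown sits.

On these data alone, whether a longer chain or a carboxylic acid at this position would give a number clearly different from that of compound 4 remains open. Compound 2 and compound 3 have no result in this assay, so they add nothing to this reading.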